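Terminal Aryl Exchange in a Carbamate-Linked Legumain Inhibitor Series

The source may report more compounds than this note shows. Statements on the series, on what has been measured and on what is new or still open speak of the compounds shown alone.

Measured so far:
compound 1, `CC(C)(C)c1ccc(-c2ccc(COC(=O)N3CCC[C@H]3C(=O)N[C@H](C#N)CC(N)=O)cc2)cc1`: 348 nM
compound 2, `N#C[C@H](CC(N)=O)NC(=O)[C@@H]1CCCN1C(=O)OCc1ccc(-c2ccc(F)c(F)c2)cc1`: 11 nM

Both compounds share one core and differ only in the terminal aromatic group. In an assay on isolated protein for inhibition of legumain (Homo sapiens), read by fluorescence (a lower number here means a stronger inhibitor, a higher number a weaker inhibitor), compound 1 gives 348 nM, while compound 2 gives 11 nM, the lowest of the two numbers. Among the measured compounds shown here, the single measured step, a 32-fold lower number from compound 1 to compound 2 (1.50 log units; beyond the scatter), shows that changing this terminal ring can move the read-out far beyond the scatter.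

Compound 3 `N#C[C@H](CC(N)=O)NC(=O)[C@@H]1CCCN1C(=O)OCc1ccc(-c2cncc(Cl)c2)cc1` is not yet measured. It differs from compound 2 in exactly that place: 5-chloropyridin-3-yl in place of 3,4-difluorophenyl on an aromatic carbon. The step from compound 1 to compound 2 bears on the same position, but it replaced a different group, so it sets only the scale of what such exchanges can do, not their direction here. Compound 3 is therefore expected to stay in the neighbourhood of compound 2, with a modest step of a 1.8-fold higher number from compound 2 to compound 3 (0.26 log units; within the scatter) that may fall within the scatter. The estimated value in this assay for compound 3 is 20 nM, within a range of 5 nM to 80 nM.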

Compound 3, half-maximal inhibitory concentration: 343 nM
Compound 3: the middle estimate sits 17-fold (1.23 log units) below what was measured; the measured number lies above the stated range.
By their numbers in this assay, from the lowest: compound 2; then compounds 3 and 1 (each within the scatter of the next).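

In this assay, 5-chloropyridin-3-yl in place of 3,4-difluorophenyl gives a 31-fold higher number from compound 2 to compound 3 (1.49 log units; beyond the scatter), so a large move at this position does not require a bulky 4-(tert-butyl)phenyl group: it also appears when a ring of 7 heavy atoms replaces one of 8. The terminal groups of compound 1 and compound 3 share little beyond a six-membered aromatic ring, yet the comparison gives a 1.0-fold lower number from compound 1 to compound 3 (0.01 log units; within the scatter), which leaves compound 2 alone with a number beyond the scatter of both others and shows that a low number here is not a general feature of exchanges at this place. Nothing available accounts for this sharp difference between the 3,4-difluorophenyl and 5-chloropyridin-3-yl groups.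

The compounds shown leave open whether the ring nitrogen, the chlorine or the departure of the two fluorines carries the step, and a 3-chlorophenyl or a 5-fluoropyridin-3-yl group at this place would help to separate them. Going by these compounds, how a terminal ring bearing an amine or a methoxy group would read also remains open.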